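Removing the methoxy group from a weak growth inhibitor

The source may hold more compounds than are shown below. What is called first, only, known or untested is meant among the compounds shown, and "the series" means these compounds.

Compound 1 `COc1ccc(-c2nc3sc(Cc4ccccc4)nn3c2SC#N)cc1`: 70800 nM
Compound 2 `O=Cc1c(-c2ccc(F)cc2)nc2sc(CCC3CCCCC3)nn12`: 93300 nM

In a functional assay on cells (Cancer cell lines, Homo sapiens) for inhibition (on this read-out lower numbers stand for stronger inhibition of growth and higher numbers for weaker inhibition of growth), compound 1 gives 70800 nM, the lowest of the two numbers shown, while compound 2 gives 93300 nM, a gap that lies within the scatter, so the two cannot be ordered. Compound 3 `N#CSc1c(-c2ccccc2)nc2sc(Cc3ccccc3)nn12` is not yet measured. It differs from compound 1 by hydrogen in place of methoxy on an aromatic carbon. Among the compounds with values here, no step between measured compounds is available to anchor this change, so the expectation is a step of a 1.1-fold higher number from compound 1 to compound 3 (0.05 log units; within the scatter), which stays within the scatter. Compound 3 is therefore estimated at 80000 nM, with a range from 30000 nM to 200000 nM.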

Compound 3, concentration for total growth inhibition: 70800 nM
Estimate against measurement, compound 3: 1.1-fold (0.05 log units) above; the measured number falls inside the stated range.
By their numbers in this assay, from the lowest: compounds 1, 3 and 2 (each within the scatter of the next).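

Hydrogen in place of methoxy on this aromatic carbon, para to a large group, gives no change at the digits printed from compound 1 to compound 3 (within the scatter) in this assay. This first step at the position shows that the 4-methoxyphenyl group of compound 1 can give way to the phenyl group of compound 3 with no loss of growth inhibition in this read-out. Nothing further is available to explain this result. Going by these compounds, whether an amine or a carboxylic acid at this place would shift the number remains open. So does whether any group here could bring the series beyond the scatter.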